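Triazole thioacetanilides: para substituent swap on the anilide ring

A few compounds are considered here, and "the series" means these few. Any claim that something is new, unique, unknown or untested is made for them only; others in the source may bear on it.

Measured in an assay on isolated protein for inhibition of long-chain fatty acid transport protein 1 (Homo sapiens); a lower number here means a stronger inhibitor, a higher number a weaker inhibitor:
- compound 1, `CCn1c(CNc2ccccc2)nnc1SCC(=O)Nc1ccc(Cl)cc1`: compound 1 gives > 1000 nM, a limit of the assay.
- compound 2, `CC/C(=N/OC)c1ccc2oc(CSc3nnc(CNc4ccccc4)n3CC)nc2c1`: compound 2 gives > 1000 nM, a limit of the assay.

Going by the values given here, compound 1 stands at the limit of this assay, and so does the one other measured compound; no numbered value exists, and no step between measured compounds can be sized. The only common ground is the limit of > 1000 nM in this assay, at which 2 of the 2 values shown sit.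

Compound 3, `CCn1c(CNc2ccccc2)nnc1SCC(=O)Nc1ccc(OC)cc1`, is the unmeasured analogue. It differs from compound 1 by methoxy in place of chloro on an aromatic carbon, with the change confined to the anilide end of the shared core.

Nothing measured speaks to the effect of this swap. Both shown values are limits, so the expectation for compound 3 rests on compound 1 alone, which gives > 1000 nM as a limit; the default is no step beyond the scatter, with compound 3 most likely reported as a limit again. Compound 3 is estimated at 2500 nM, within 800 nM to 8000 nM. The expected step is a step that the limit leaves unreadable from compound 1 to compound 3, none beyond the scatter.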

Compound 3, half-maximal inhibitory concentration: > 1000 nM
Compound 3: no number, only a limit; the forecaster's own chance of this, stated with the estimate: 80%; the middle value lies beyond the limit too.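

In this assay compound 3 gives > 1000 nM, a limit of the assay. No step can be read between compound 1 and compound 3, because both sit at the same limit: the limit of > 1000 nM in this assay, at which 3 of the 3 values shown sit.

The compounds shown leave open whether methoxy in place of chloro changes inhibition at all, and which change to the shared core would give a numbered value.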